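The source may hold more compounds than are shown below. What is called first, only, known or untested is meant among the compounds shown, and "the series" means these compounds.

Measured so far:
compound 1 `COc1ccc(N)c(C(=O)CCNC(=O)C2CC2)c1`: 99.9%
compound 2 `Nc1ccc(Cl)cc1C(=O)CCNC(=O)C1CC1`: "not determined" (no result reported)

Compound 1 stands alone with a number. In a functional assay for inhibition of kynurenine 3-monooxygenase (Rattus norvegicus), tested at 1 mM (on this read-out lower numbers stand for less inhibition and higher numbers for more inhibition at the one concentration tested (going by the name of the read-out)), compound 1 gives 99.9%, a high number on this read-out at the single concentration tested. Compound 2 is reported as "not determined" (no result reported) in this assay, so it offers no comparison. Compound 3 `CCCCC(=O)NCCC(=O)c1cc(OC)ccc1N` differs from compound 1 in one place (butyl in place of cyclopropyl on a carbonyl carbon). Among the measured compounds shown here, no step between measured compounds is available to gauge this change. Since compound 1 already gives 99.9%, a high number on this read-out, the step of a number 5.9 percentage points lower from compound 1 to compound 3 (within the scatter) is expected to be none beyond the scatter, with any deviation more likely downward than upward. Compound 3 is therefore expected to give 94%, between 78% and 100%.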

Compound 3, a percentage reported as inhibition, at one concentration (the size of the read-out at that concentration, not a potency): 97.2%
Estimate against measurement, compound 3: 3.2 percentage points below, within the range that was stated.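

In this assay, butyl in place of cyclopropyl on a carbonyl carbon gives a number 2.7 percentage points lower from compound 1 to compound 3 (within the scatter). This place therefore accepts an open chain as well as the three-membered ring, and the ring is not required to keep the read-out high at the one concentration tested. No evidence is available to explain this result. Both values lie high on the read-out, so a smaller difference between the two groups could go unseen. Going by these compounds, whether an amine, a carboxylic acid or a longer chain at this place would keep the read-out as high remains open.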